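Swapping naphthyl for biphenyl in a cytotoxicity series

A few compounds are considered here, and "the series" means these few. Any claim that something is new, unique, unknown or untested is made for them only; others in the source may bear on it.

Compound 2 `CCOC(=O)CCCCCOc1cccc(CN(C(=O)c2ccc(-c3cccc4ccccc34)cc2)C(C)C)c1` has been tested in an ADME assay on HepG2 cells (Homo sapiens) for cytotoxicity, read by CellTiter-Glo and resazurin assay, with a stated time of 72 h; a higher number here means that more compound is needed for the effect, a lower number that less compound is needed. In this assay compound 2 gives > 26000 nM, and this is a limit of the assay. Its closest measured relative is compound 1 `CC(C)N(Cc1cccc(OCCCCCC(=O)O)c1)C(=O)c1ccc(-c2cccc3ccccc23)cc1`, which differs only by ethyl in place of hydrogen on an oxygen next to a carbonyl group. In this assay compound 1 gives > 26000 nM, which is also a limit. The step that the two limits leave unreadable from compound 1 to compound 2 therefore cannot be sized, since the limit of > 26000 nM in this assay, at which 2 of the 2 values shown sit, is where both values sit. The untested compound 3 `CCOC(=O)CCCCCOc1cccc(CN(C(=O)c2ccc(-c3cccc(-c4ccccc4)c3)cc2)C(C)C)c1` carries a different change: 3-phenylphenyl in place of naphthalen-1-yl on an aromatic carbon. For the measured compounds named here, no measured step touches this part of the molecule, so the only guidance is that both measured compounds rest at the limit of > 26000 nM in this assay, at which 2 of the 2 values shown sit. Compound 3 is expected to show a step that the limit leaves unreadable from compound 2 to compound 3 in this assay, most likely again only a limit. Compound 3 is estimated at 30000 nM, within a range from 12000 nM to 100000 nM.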

Compound 3, half-maximal effective concentration: > 26000 nM
Compound 3: only a limit was reported; the forecaster's own chance of this, stated with the estimate: 80%; the middle value lies beyond the limit too.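

In this assay compound 3 gives > 26000 nM, which is again a limit, so no size can be read for the step from compound 2 to compound 3. The compounds shown leave open whether 3-phenylphenyl and naphthalen-1-yl differ at all in cytotoxicity, as every result rests at one point: the limit of > 26000 nM in this assay, at which 3 of the 3 values shown sit.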